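The compounds below may be only part of what the source reports. "The series", "measured", "known", "first", "only" and "open" are said of these compounds alone.

Compound 1 `N=C(NCCCc1c[nH]cn1)NCCC(c1ccc(Cl)cc1)c1ccccn1`: 77.6 nM
Compound 2 `N=C(NCCCc1c[nH]cn1)NCCC(c1cccc(C(F)(F)F)c1)c1ccccn1`: 525 nM

Going by the values given here, in a functional assay on ileum for antagonist activity at histamine H1 receptor (Cavia porcellus) (a lower number here means tighter binding, a higher number weaker binding), compound 2 holds the higher of the two numbers measured so far; its nearest neighbour is compound 1, and the only measured step, a 6.8-fold higher number from compound 1 to compound 2 (0.83 log units; beyond the scatter), shows that swapping the ring at this position moves the number beyond the usual scatter. Compound 3 `N=C(NCCCc1c[nH]cn1)NCCC(c1ccccn1)c1ccccn1` is reached from compound 2 by the change (pyridin-2-yl in place of 3-(trifluoromethyl)phenyl on a saturated chain carbon bound to an aromatic carbon and a saturated chain carbon), so that both rings on that chain carbon are now pyridin-2-yl. Among the compounds with values here, no measured pair tells how a pyridin-2-yl behaves there; the step of a 6.8-fold higher number from compound 1 to compound 2 (0.83 log units; beyond the scatter) only marks the size a ring change at this place can reach, and there is no second step to show a trend. The estimate therefore leans toward a modest move back toward the number of compound 1, but with wide uncertainty. For compound 3 the expected value in this assay is 300 nM (range 60 nM to 1500 nM), which would mean an expected step of a 1.8-fold lower number from compound 2 to compound 3 (0.24 log units; within the scatter).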

Compound 3, dissociation constant: 389 nM
Compound 3: the middle estimate sits 1.3-fold (0.11 log units) below what was measured; the range from low to high includes it.
By their numbers in this assay, from the lowest: compound 1; then compounds 3 and 2 (each within the scatter of the next).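

In this assay, pyridin-2-yl in place of 3-(trifluoromethyl)phenyl gives a 1.3-fold lower number from compound 2 to compound 3 (0.13 log units; within the scatter), so these two groups cannot be told apart at this position, even though they differ in size and only pyridin-2-yl counts a hydrogen-bond acceptor. Among the three groups shown, 4-chlorophenyl stands apart, as pyridin-2-yl in its place gives a 5.0-fold higher number from compound 1 to compound 3 (0.70 log units; beyond the scatter), a step beyond the scatter, like the one from compound 1 to compound 2. No available evidence explains these results.

The compounds shown leave open whether the lower number of compound 1 depends on the chlorine itself or on the ring that carries it, which a plain phenyl or a 4-fluorophenyl group at this position could help separate. They also leave open how much the other pyridin-2-yl group, present in all three compounds, contributes.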